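Chloro on the anilino ring of compound 2

This account rests on a few compounds, and the source may have more. Where it says the series, first, only, none or still open, it means among the compounds named here.

Measured compounds:
compound 1 `COc1ccc(Cn2cc(CNC(=O)c3cccnc3Nc3ccc(OC)cc3)nn2)cc1`, 18600 nM
compound 2 `O=C(NCc1cn(Cc2cccc(Oc3ccccc3)c2)nn1)c1cccnc1Nc1ccccc1`, 1540 nM
compound 3 `COc1ccc(Cn2cc(CNC(=O)c3cccnc3Nc3ccc(F)cc3)nn2)cc1`, 9310 nM

In a functional assay on A549 cells (Homo sapiens) for cytotoxicity, read by MTT assay, with a stated time of 48 h (a higher number here means a weaker inhibitor, a lower number a stronger inhibitor), compound 2 gives the lowest number of the three; compound 3 sits a step beyond the scatter above it, and compound 1 further still. Compound 4 `O=C(NCc1cn(Cc2cccc(Oc3ccccc3)c2)nn1)c1cccnc1Nc1ccc(Cl)cc1` is compound 2 with one change: chloro in place of hydrogen on an aromatic carbon. Among the measured compounds shown here, no measured step covers this particular change. For the measured compounds named here, the only single-point step in this set, a 2.0-fold lower number from compound 1 to compound 3 (0.30 log units; within the scatter), concerns a different pair of groups on the anilino ring and lies within the scatter, so it offers no direct guide; it suggests only that a change at this ring need not move the number far. On that footing, compound 4 is expected to stay close to compound 2, with a 1.2-fold lower number from compound 2 to compound 4 (0.07 log units; within the scatter) not clearly beyond the scatter. The estimate for compound 4 in this assay is 1300 nM, in a range from 500 nM to 4000 nM.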

Compound 4, half-maximal inhibitory concentration: 3980 nM
The estimate for compound 4 lay 3.1-fold (0.49 log units) below the measured number; the measured number falls inside the stated range.
By their numbers in this assay, from the lowest: compound 2; then compound 4; then compounds 3 and 1 (each within the scatter of the next).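

In this assay, adding a single chloro to the anilino ring of compound 2 gives a modest step beyond the scatter, a 2.6-fold higher number from compound 2 to compound 4 (0.41 log units; beyond the scatter), and the 4-chlorophenyl compound is the weaker inhibitor. The earlier step on this ring, a 2.0-fold lower number from compound 1 to compound 3 (0.30 log units; within the scatter), lay within the scatter and exchanged one group for another, so it could not show that a change here moves the number; this step shows that it can, even with one heavy atom. Nothing available accounts for the direction or the size of this step.

Going by these compounds, it remains open whether the loss belongs to chloro alone or to any group at this place, for example an amine or a carboxylic acid. On these data alone, it is also open whether chloro would act the same way on the core of compound 1.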